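Replacing the Acid of Compound 3 with a Pyrrolidine Amide

This account rests on a few compounds, and the source may have more. Where it says the series, first, only, none or still open, it means among the compounds named here.

Compound 3 `O=C(O)[C@@H]1C[C@H]1c1ccc(NCc2cccc(Oc3ccccc3)c2)cc1` stands second highest of the three compounds measured in a functional assay on CHO cells for agonist activity at Free fatty acid receptor 1 (Homo sapiens), read by a luciferase reporter (on this read-out lower numbers stand for smaller maximal responses and higher numbers for larger maximal responses), where compound 3 gives 64%. Compound 2 `CC(CC(=O)O)c1ccc(NCc2cccc(Oc3ccccc3)c2)cc1` gives 83% in this assay, and compound 1 `CC(C)(Oc1ccc(NCc2cccc(Oc3ccccc3)c2)cc1)C(=O)O` gives 14%. Both neighbours differ from compound 3 only in the group that carries the carboxylic acid: a number 19 percentage points lower from compound 2 to compound 3 (beyond the scatter) and a number 50 percentage points higher from compound 1 to compound 3 (beyond the scatter), while a number 69 percentage points higher from compound 1 to compound 2 (beyond the scatter).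

Compound 4 `O=C(CCc1ccc(NCc2cccc(Oc3ccccc3)c2)cc1)N1CCCC1` carries instead (2-((pyrrolidin-1-yl)carbonyl)ethyl in place of 2-carboxycyclopropyl on an aromatic carbon). Within the data shown here, this change removes the carboxylic acid that all three measured compounds share, so none of the measured steps bears on it directly; each of them only reshaped the link between the aromatic carbon and the acid, yet even those reshapings moved the maximal response well beyond the scatter. With the acid replaced by an amide, the expected step in this assay is a fall beyond the scatter, a number 39 percentage points lower from compound 3 to compound 4 (beyond the scatter), although its size cannot be read from three acids alone. Compound 4 is therefore estimated at 25% in this assay, with a range from 5% to 60%.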

Compound 4, largest response reached (reported as percent of maximum), in percent of the reference or control that the assay uses: 46%
The estimate for compound 4 lay 21 percentage points below the measured number; low and high end bracket the measured number.
By their numbers in this assay, from the lowest: compound 1; then compound 4; then compound 3; then compound 2.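

Compound 4 shows that, on an aromatic carbon para to a large group, a carboxylic acid is not needed for a clear response in this assay: the 2-((pyrrolidin-1-yl)carbonyl)ethyl amide loses only a modest amount against the cyclopropyl acid (a number 18 percentage points lower from compound 3 to compound 4 (beyond the scatter)). Its place among the acids depends on the acid used for comparison, since it falls well short of one (a number 37 percentage points lower from compound 2 to compound 4 (beyond the scatter)) yet clearly exceeds another (a number 32 percentage points higher from compound 1 to compound 4 (beyond the scatter)), so the link carrying the acid can matter as much here as the acid itself. Nothing available explains this order.

The compounds shown leave open how a 2-carboxyethyl group would compare, so the effect of the amide cannot be separated from the loss of the three-membered ring. As far as these compounds go, whether a dimethylamide or a piperidine amide would match the pyrrolidine amide also remains open.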